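The source may report more compounds than this note shows. Statements on the series, on what has been measured and on what is new or still open speak of the compounds shown alone.

For the measured compounds named here, compound 1, `CSc1nn(-c2ccccc2)c2ncnc(N/N=C/c3ccc(Br)cc3)c12`, is the stronger-looking of the two compounds measured so far only on paper: in a functional assay on MCF7 cells (Homo sapiens) for inhibition, read by sulforhodamine B assay, with a stated time of 48 h (a higher number here means a weaker inhibitor, a lower number a stronger inhibitor), compound 1 gives 10.9 nM, while compound 2, `CSc1nn(-c2ccccc2)c2ncnc(N/N=C/c3ccccc3O)c12`, gives 10.7 nM in this assay, and the step of a 1.0-fold lower number from compound 1 to compound 2 (0.01 log units; within the scatter) is within the scatter, so neither can be called the more potent. Compound 3, `CSc1nn(-c2ccccc2)c2ncnc(N/N=C/c3ccc(O)cc3)c12`, has not yet been measured. It differs from compound 1 as follows: hydroxy in place of bromo on an aromatic carbon. Going by the values given here, only one measured step bears on this change. Moving from compound 1 to compound 2 exchanged the same 4-bromophenyl for a 2-hydroxyphenyl on the carbon with a double bond to nitrogen, and that step, a 1.0-fold lower number from compound 1 to compound 2 (0.01 log units; within the scatter), was within the scatter. Among the compounds with values here, the change to compound 3 puts a hydroxy at a different place on the same ring, so the one relevant precedent points to no step beyond the scatter. He therefore expects the step of a 1.0-fold higher number from compound 1 to compound 3 (0.00 log units; within the scatter) to be essentially flat. The estimate for compound 3 in this assay is 11 nM, with a range from 5 nM to 25 nM.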

Compound 3, half-maximal inhibitory concentration: 10.3 nM
Compound 3: middle estimate off by 1.1-fold (0.03 log units), on the high side; measured number inside the range.
By their numbers in this assay, from the lowest: compounds 3, 2 and 1 (each within the scatter of the next).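

In this assay, for the compounds shown here, a bromo and a hydroxy on this aromatic carbon, para to a large group, could not be told apart (a 1.1-fold lower number from compound 1 to compound 3 (0.02 log units; within the scatter)), and this is the first direct exchange of the two groups at the same place, since the earlier step had also shifted the substituent on the ring. The new compound also allows the hydroxy to be compared at two places on the same ring, and the 2-hydroxyphenyl and 4-hydroxyphenyl compounds do not separate either (a 1.0-fold lower number from compound 2 to compound 3 (0.02 log units; within the scatter)), so among these three compounds neither the identity of this substituent nor the place of the hydroxy moves the number beyond the scatter. Nothing in the data shown explains this flat result.

Three compounds in a single cell assay cannot show whether a methoxy, an amine or a carboxylic acid on this aromatic carbon would also stay within the scatter, or whether a longer chain there would break the pattern. They also leave open how the assay responds to changes elsewhere, since the methylthio and phenyl groups on the shared core stay the same throughout.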